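Methyl for Trifluoromethyl on the Sulfur-Containing Core

The compounds below may be only part of what the source reports. "The series", "measured", "known", "first", "only" and "open" are said of these compounds alone.

Measured so far in a physicochemical assay for lipophilicity; a lower number here means a more polar compound, a higher number a more lipophilic compound:
Compound 1, `CN1C=CN(C2OC(C(F)(F)F)=CN2c2ccc(S(N)(=O)=O)cc2)C=C1`, gives 1.68.
Compound 2, `CC1=CN(c2ccc(S(N)(=O)=O)cc2)C(N2C=CN(C)C=C2)O1`, gives 1.04.
Compound 3, `CN1C=CN(C2SC(C(F)(F)F)=CN2c2ccc(S(N)(=O)=O)cc2)C=C1`, gives 2.38.

From compound 1 to compound 2 the change is methyl in place of trifluoromethyl on a double-bonded ring carbon, and in this assay it made a number 0.64 log units lower from compound 1 to compound 2 (beyond the scatter). Compound 3 stands highest of the three; the difference between its core and that of compound 1 is not broken down here. Compound 4, `CC1=CN(c2ccc(S(N)(=O)=O)cc2)C(N2C=CN(C)C=C2)S1`, is not yet measured. It differs from compound 3 by methyl in place of trifluoromethyl on a double-bonded ring carbon. This is the same kind of change as that from compound 1 to compound 2, though the place differs: there the ring has 1 nitrogen and 1 oxygen and the carbon is next to the ring oxygen, here the ring has 1 nitrogen and 1 sulfur and the carbon is next to the ring sulfur. Resting on a number 0.64 log units lower from compound 1 to compound 2 (beyond the scatter), the step from compound 3 to compound 4 is expected to be a number 0.64 log units lower from compound 3 to compound 4 (beyond the scatter). Compound 4 is therefore estimated at 1.74, expected between 1.4 and 2.1.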

Compound 4, partition coefficient: 1.75
Compound 4: the middle estimate sits 0.01 log units below what was measured; the measured number falls inside the stated range.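

In this assay, methyl in place of trifluoromethyl on a double-bonded ring carbon gave a number 0.63 log units lower from compound 3 to compound 4 (beyond the scatter) on the ring with 1 nitrogen and 1 sulfur, which has the same direction and nearly the same size as a number 0.64 log units lower from compound 1 to compound 2 (beyond the scatter) on the ring with 1 nitrogen and 1 oxygen. This shows that the step carried over between these two cores, but with one pair on each core it sets no rule for other cores or other ring places. Nothing at hand accounts for the agreement between the two steps.

The compounds shown leave open whether the step would carry over in the same way for another group on that double-bonded ring carbon, such as a chlorine, a nitrile or an ethyl. They also leave open how an amine or a carboxylic acid there would compare on the two cores.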